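The compounds below may be only part of what the source reports. "The series", "measured", "known", "first", "only" and "open" are said of these compounds alone.

Working notes on the series, read in a functional assay on SGC-7901 cells (Homo sapiens) for cytotoxicity, read by sulforhodamine B assay, with a stated time of 72 h; a higher number here means a weaker inhibitor, a lower number a stronger inhibitor. Compound 1 `C=C1C(=O)O[C@@H]2CC(C)=C([C@@H](C)CCCOC(C)=O)[C@@H](OC(=O)CN3CCCC3)[C@H]12` gives 18400 nM. Compound 2 `C=C1C(=O)O[C@@H]2CC(C)=C([C@@H](C)CCCOC(C)=O)[C@@H](OC(=O)COc3cccc4cccnc34)[C@H]12` gives 14300 nM. Compound 3 `C=C1C(=O)O[C@@H]2CC(C)=C([C@@H](C)CCCOC(C)=O)[C@@H](OC(=O)c3ccccc3F)[C@H]12` gives 19300 nM, which places it level with the other two, so the three values support no ranking.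

Compound 4 `C=C1C(=O)O[C@@H]2CC(C)=C([C@@H](C)CCCOC(C)=O)[C@@H](OC(=O)c3cccc(F)c3)[C@H]12` has 3-fluorophenyl in place of 2-fluorophenyl on a carbonyl carbon. Going by the values given here, no measured step exchanges one fluorophenyl group for another, so the evidence bearing on this change is indirect. The closest evidence comes from the two steps that change the group on that same carbonyl carbon and end at compound 3: a 1.0-fold higher number from compound 1 to compound 3 (0.02 log units; within the scatter) and a 1.3-fold higher number from compound 2 to compound 3 (0.13 log units; within the scatter). The remaining step, a 1.3-fold lower number from compound 1 to compound 2 (0.11 log units; within the scatter), is also small. Even these exchanges of quite different groups stayed within the scatter, so the swap in compound 4, which keeps the same atoms, is not expected to produce a step beyond the scatter in this assay, and no direction is favoured. The estimated step is a 1.1-fold lower number from compound 3 to compound 4 (0.06 log units; within the scatter). Compound 4 is estimated at 17000 nM, with an expected range from 9000 nM to 30000 nM.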

Compound 4, half-maximal inhibitory concentration: 12900 nM
Compound 4: middle estimate off by 1.3-fold (0.12 log units), on the high side; the range from low to high includes it.
By their numbers in this assay, from the lowest: compounds 4, 2, 1 and 3 (each within the scatter of the next).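

Going by these compounds alone, exchanging 2-fluorophenyl for 3-fluorophenyl on this carbonyl carbon gives the only direct reading of a fluorophenyl exchange: a 1.5-fold lower number from compound 3 to compound 4 (0.17 log units; within the scatter) in this assay, a step that stays within the scatter. The exchanges of 3-fluorophenyl for the two non-aromatic-linked side groups read the same way, with ((quinolin-8-yl)oxy)methyl replaced in a 1.1-fold lower number from compound 2 to compound 4 (0.04 log units; within the scatter) and (pyrrolidin-1-yl)methyl replaced in a 1.4-fold lower number from compound 1 to compound 4 (0.15 log units; within the scatter), and neither step leaves the scatter. The series therefore still supports no ranking, now with a fluorophenyl isomer pair included, and nothing available here accounts for the values sitting together.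

Going by these compounds, whether 4-fluorophenyl, a carboxylic acid or a longer chain on this carbonyl carbon would give a step beyond the scatter in this assay remains open. Also open, on these data alone, is whether a change elsewhere on the shared core, away from this carbonyl carbon, would move the number further than any exchange at this position has done.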